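The source may hold more compounds than are shown below. What is called first, only, known or untested is meant among the compounds shown, and "the series" means these compounds.

Measured compounds in an assay for inhibition of alcohol dehydrogenase (Equus caballus), read by spectrophotometry, in the presence of a further agent that is not named here; a higher number here means weaker binding, a lower number tighter binding:
Compound 1 `ClCCCc1cc[nH]n1` gives 40000 nM.
Compound 2 `ClCc1cn[nH]c1` gives 2700 nM.

Compound 2 holds the lower of the two numbers in this assay, and the gap to compound 1 lies beyond the usual scatter. Compound 3 `OCCCc1cn[nH]c1` keeps the core of compound 2 and differs from it in one place: 2-hydroxyethyl in place of chloro on a saturated chain carbon bound to an aromatic carbon. No comparable change between measured compounds is known, so the size of this step cannot be read from the data. The step from compound 2 to compound 3 is expected to be small, a 1.3-fold higher number from compound 2 to compound 3 (0.11 log units; within the scatter), likely within the scatter or slightly toward weaker binding. Compound 3 is accordingly estimated at 3500 nM, within a range of 900 nM to 14000 nM.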

Compound 3, dissociation constant: 560 nM
Beside the measured number, compound 3's estimate is 6.3-fold (0.80 log units) above it, and the stated range ends above it.
By their numbers in this assay, from the lowest: compound 3; then compound 2; then compound 1.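

In this assay, replacing chloro with 2-hydroxyethyl on the saturated chain carbon bound to an aromatic carbon gives a 4.8-fold lower number from compound 2 to compound 3 (0.68 log units; beyond the scatter), a modest shift toward tighter binding. This position therefore accepts a larger group bearing a hydrogen-bond donor and acceptor without loss of binding. Nothing measured here assigns the gain to the oxygen, the added carbons or the departure of chlorine. On these data alone, it remains open whether the hydroxyl or the chain length matters more. An amine at the chain end, a methoxy group or a longer chain ending in hydroxyl would bear on that question.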